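Trifluoromethoxy replacing trifluoromethyl in a hydroxy-substituted enone series

The source may hold more compounds than are shown below. What is called first, only, known or untested is meant among the compounds shown, and "the series" means these compounds.

Compound 1, `O=C1/C(=C/c2ccc(F)cc2)CCc2ccc(O)cc21`, is measured in a functional assay on RAW264.7 cells (Mus musculus) for inhibition (on this read-out lower numbers stand for stronger inhibition and higher numbers for weaker inhibition), and gives 840 nM. Compound 2, `O=C1/C(=C/c2ccc(C(F)(F)F)cc2)CCc2ccc(O)cc21`, carries trifluoromethyl in place of fluoro on an aromatic carbon. In this assay compound 2 reaches only a limit of the assay, > 10000 nM, and not a number. One of the two values sits at the limit of > 10000 nM in this assay, at which 1 of the 2 values shown sits. The step is therefore an at least 11-fold higher number from compound 1 to compound 2 (1.07 log units; beyond the scatter), and compound 2 stands at the weak end of the two values shown, with its number known only as a bound.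

Compound 3, `O=C1/C(=C/c2ccc(OC(F)(F)F)cc2)CCc2ccc(O)cc21`, differs from compound 2 by trifluoromethoxy in place of trifluoromethyl on an aromatic carbon. Among the compounds with values here, the single measured step, the large loss from compound 1 to compound 2, bears on this change only indirectly, since the trifluoromethyl carbon and its three fluorines remain in compound 3 and an oxygen is added. Within the data shown here, with no measured step that isolates such an addition, no step beyond the scatter is expected, and compound 3 is expected to sit near the limit, which the expected step of an at least 1.1-fold lower number from compound 2 to compound 3 (0.04 log units; that floor lies within the scatter) reflects. The estimate for compound 3 in this assay is 9000 nM, within 3000 nM to 30000 nM.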

Compound 3, half-maximal inhibitory concentration: 980 nM
Compound 3: the middle estimate sits 9.2-fold (0.96 log units) above what was measured, outside the stated range (below it).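

In this assay, the result shows that the loss seen with trifluoromethyl does not extend to every fluorinated group on this aromatic carbon, para to a large group: the change to trifluoromethoxy gives an at least 10-fold lower number from compound 2 to compound 3 (1.00 log units; beyond the scatter). Set against fluoro, the same group gives a 1.2-fold higher number from compound 1 to compound 3 (0.07 log units; within the scatter), so the two substituents cannot be told apart here, and the heavy-atom count alone does not set the read-out, as trifluoromethoxy has more heavy atoms than the trifluoromethyl that falls at the weak end. The recovery from compound 2 has a floor and no measured size, because compound 2 stands at a limit of the assay and not at a number: the limit of > 10000 nM in this assay, at which 1 of the 3 values shown sits.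

The compounds shown leave open how far this tolerance reaches at the same position, for example with methoxy, which would keep the oxygen without the fluorines, or with an amine, a carboxylic acid or a longer alkoxy chain. They also leave open what the hydroxy group on the shared core contributes, as it is the same in all three compounds.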